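The source may hold more compounds than are shown below. What is called first, only, known or untested is meant among the compounds shown, and "the series" means these compounds.

Measured so far:
- Compound 1 `CCn1ncnc1-c1ccccc1NCC1=NCCN1`: 94%
- Compound 2 `Cc1n[nH]c(-c2ccccc2NCC2=NCCN2)n1`: 0%
- Compound 3 `CCCCn1ncnc1-c1ccccc1NCC1=NCCN1`: 83%

In a functional assay with Alpha-1B adrenergic receptor (Homo sapiens) as the target, read by calcium flux (a higher number here means a larger maximal response, a lower number a smaller maximal response), compound 3 stands second highest of the three. Its nearest neighbour on the numbers is compound 1, which gives 94% in this assay, while compound 2 lies far lower with 0%. Compound 4 `Cn1ncnc1-c1ccccc1NCC1=NCCN1` arises from compound 3 by a single change: hydrogen in place of propyl on a saturated chain carbon bound to an aromatic nitrogen. For the measured compounds named here, the one measured step that bears on this is the lengthening of the same chain, a number 11 percentage points lower from compound 1 to compound 3 (beyond the scatter), which moved the maximal response only modestly. Compound 4 shortens the chain in the opposite sense, so a modest rise or no change beyond the scatter is expected, a number 9 percentage points higher from compound 3 to compound 4 (within the scatter). Compound 4 is therefore estimated at 92%, with a likely range from 78% to 100%.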

Compound 4, largest response reached (reported as maximal response), in percent of the reference or control that the assay uses: 93%
Beside the measured number, compound 4's estimate is 1 percentage points below it; measured number inside the range.
By their numbers in this assay, from the lowest: compound 2; then compounds 3, 4 and 1 (each within the scatter of the next, the first and the last beyond it).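

In this assay, hydrogen in place of propyl on a saturated chain carbon bound to an aromatic nitrogen gives a number 10 percentage points higher from compound 3 to compound 4 (within the scatter) and hydrogen in place of methyl there gives a number 1 percentage points lower from compound 1 to compound 4 (within the scatter), so trimming the chain to a single methyl keeps the response. By contrast, 1-methyl-1H-1,2,4-triazol-5-yl in place of 3-methyl-1H-1,2,4-triazol-5-yl on an aromatic carbon gives a number 93 percentage points higher from compound 2 to compound 4 (beyond the scatter), a far larger step than any chain change here. Nothing measured here gives a reason for these numbers. Still open, from the compounds shown here alone, is how a chain ending in an amine or a carboxylic acid would read in this position.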